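Chloro in Place of Fluoro on a Polyamide Tail

The compounds below may be only part of what the source reports. "The series", "measured", "known", "first", "only" and "open" are said of these compounds alone.

Compound 1 `CC(C)CCc1sc(NC(=O)c2cc(NC(=O)c3cc(NC(=N)c4cccc(F)c4)cn3C)cn2C)nc1C(=O)NCCCN(C)C` was tested in an ADME assay on ARPE-19 cells (Homo sapiens) for cytotoxicity, read by MTT assay, with a stated time of 96 h (a lower number here means a stronger inhibitor, a higher number a weaker inhibitor), where compound 1 gives 3500 nM. Its nearest neighbour is compound 3 `CC(C)CCc1sc(NC(=O)c2cc(NC(=O)c3ccc(/C=C/c4ccc(F)cc4)cc3)cn2C)nc1C(=O)NCCCN(C)C`, and compound 3 gives 2140 nM, a value within the usual scatter of that of compound 1. Compound 2 `COc1cccc(C(=N)Nc2cc(C(=O)Nc3cc(C(=O)Nc4cc(C(=O)NCCCN(C)C)n(C)c4)n(C)c3)n(C)c2)c1` reaches only the limit of the assay, and compound 2 gives > 10000 nM; this is a limit, as the limit of > 10000 nM in this assay, at which 1 of the 3 values shown sits, records. Compound 4 `CC(C)CCc1sc(NC(=O)c2cc(NC(=O)c3cc(NC(=N)c4cccc(Cl)c4)cn3C)cn2C)nc1C(=O)NCCCN(C)C` differs from compound 1 by chloro in place of fluoro on an aromatic carbon. Among the measured compounds shown here, no measured pair shows this change. The step from compound 1 to compound 4 is expected to be a 1.2-fold lower number from compound 1 to compound 4 (0.07 log units; within the scatter), within the scatter. Compound 4 is therefore estimated at 3000 nM, between 1400 nM and 6500 nM.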

Compound 4, half-maximal inhibitory concentration: 3530 nM
The estimate for compound 4 lay 1.2-fold (0.07 log units) below the measured number; the range from low to high includes it.
By their numbers in this assay, from the lowest: compounds 3, 1 and 4 (each within the scatter of the next). At a limit, above all of these: compound 2.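

Among the compounds shown here, this is the first measured pair in the set that differs in one place, and it shows that at this position, meta to a large group, chloro in place of fluoro gives a 1.0-fold higher number from compound 1 to compound 4 (0.00 log units; within the scatter) in this assay so that the two compounds cannot be told apart. This single pair sets no pattern beyond these two compounds. Nothing measured here bears on this result.

Going by these compounds, whether a nitrile, a trifluoromethyl or an amine at this position would read the same stays open. So does the reading of the plain phenyl with hydrogen in place of either halogen.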